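Swapping the aryl group on an inactive trifluoromethyl compound

The source may hold more compounds than are shown below. What is called first, only, known or untested is meant among the compounds shown, and "the series" means these compounds.

- compound 1 `CCc1nc(-c2ccccc2F)c(C(=O)N2CCN(c3cccc(Cl)c3)CC2)o1` gives 139 nM
- compound 2 `O=C(c1oc(C(F)(F)F)nc1-c1ccccc1F)N1CCN(c2cccc(Cl)c2)CC1` gives "not active" (no number reported)
- compound 3 `COc1cc(OC)cc(N2CCN(C(=O)c3oc(C)nc3-c3ccccc3F)CC2)c1` gives 10.3 nM

For the measured compounds named here, in a functional assay on HL-60 cells (Homo sapiens) for inhibition, read by MTT assay, with a stated time of 72 h (a lower number here means a stronger inhibitor, a higher number a weaker inhibitor), compound 1 and compound 3 have numbers, whereas compound 2 has none, only the report "not active" (no number reported) (so no step can be sized from it).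

Compound 4 `O=C(c1oc(C(F)(F)F)nc1-c1cccc(Cl)c1)N1CCN(c2cccc(Cl)c2)CC1` keeps the trifluoromethyl group of compound 2 and carries 3-chlorophenyl in place of 2-fluorophenyl on an aromatic carbon. Going by the values given here, no measured pair shows this swap alone, and neither compound 1 nor compound 3 carries the trifluoromethyl group, so the evidence is thin. A modest step toward stronger inhibition is expected, perhaps enough to give a readable but weak number. That expectation starts from compound 2 at "not active" (no number reported) and leaves a real chance that compound 4 also receives no number. In this assay the estimated value for compound 4 is 1500 nM with an expected range from 150 nM to 15000 nM as its bounds.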

Compound 4, half-maximal inhibitory concentration: "not active" (no number reported)
The entry for compound 4 holds no number; the estimate stays without a comparison.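

In this assay compound 2 and compound 4 are both reported as not active, without a number, so no step can be read between them, and no evidence bears on this result. From the compounds shown here alone, whether 3-chlorophenyl in place of 2-fluorophenyl changes inhibition at all remains open.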